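Shifting the Methyl on a Pyridinyl Carbonyl Group

The source may hold more compounds than are shown below. What is called first, only, known or untested is meant among the compounds shown, and "the series" means these compounds.

Measured compounds:
compound 1, `Cc1ccc(-c2nn(-c3ccccc3)cc2-c2nc3ccccc3n2C(=O)c2ccccc2)cc1`: 204000 nM
compound 2, `Cc1ccc(-c2nn(-c3ccccc3)cc2-c2nc3ccccc3n2C(=O)c2cncc(C)c2)cc1`: 155000 nM

In an ADME assay on HEK-293T cells (Homo sapiens) for cytotoxicity, read by MTT assay, with a stated time of 24 h (on this read-out lower numbers stand for higher toxicity in this test and higher numbers for lower toxicity in this test), compound 1 gives 204000 nM and compound 2 gives 155000 nM. Compound 2 shows the lowest of the two numbers, with compound 1 its nearest neighbour, but the step of a 1.3-fold lower number from compound 1 to compound 2 (0.12 log units; within the scatter) lies within the scatter, so the two compounds cannot be ranked against each other on this read-out.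

Compound 3, `Cc1ccc(-c2nn(-c3ccccc3)cc2-c2nc3ccccc3n2C(=O)c2ccc(C)nc2)cc1`, has not yet been measured in this assay. It differs from compound 2 in one place: 6-methylpyridin-3-yl in place of 5-methylpyridin-3-yl on a carbonyl carbon. Within the data shown here, the only measured step that bears on this position, a 1.3-fold lower number from compound 1 to compound 2 (0.12 log units; within the scatter), exchanged phenyl for 5-methylpyridin-3-yl on the same carbonyl carbon and stayed within the scatter. The change from compound 2 to compound 3 is smaller again, since the two have the same atoms joined differently, so no step beyond the scatter is expected; the estimated step is a 1.0-fold higher number from compound 2 to compound 3 (0.01 log units; within the scatter). Compound 3 is therefore expected near 160000 nM, with a range from 80000 nM to 320000 nM.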

Compound 3, half-maximal cytotoxic concentration: 145000 nM
The estimate for compound 3 lay 1.1-fold (0.04 log units) above the measured number, within the range that was stated.
By their numbers in this assay, from the lowest: compounds 3, 2 and 1 (each within the scatter of the next).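

In this assay, moving the methyl from 5-methylpyridin-3-yl to 6-methylpyridin-3-yl, on a carbonyl carbon whose other neighbours are aromatic nitrogen, gives a 1.1-fold lower number from compound 2 to compound 3 (0.03 log units; within the scatter), so the two groups cannot be told apart on this read-out. The exchange of phenyl for 6-methylpyridin-3-yl on the same carbon gives a 1.4-fold lower number from compound 1 to compound 3 (0.15 log units; within the scatter), which places this group, like 5-methylpyridin-3-yl before it, within the scatter of phenyl and shows that the place of the methyl on the pyridine ring makes no readable difference among these compounds. No supporting information is available that would explain this result.

The three compounds leave open whether a group of another kind on this carbonyl carbon, such as an amine, a carboxylic acid or a longer alkyl chain, would take the number beyond the scatter. They also leave open how plain pyridin-3-yl, without any methyl, would stand beside these groups, and whether changes elsewhere on the shared core would matter more.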